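The source may hold more compounds than are shown below. What is called first, only, known or untested is meant among the compounds shown, and "the series" means these compounds.

Compound 1 `CCC(/N=C(\NC#N)Nc1ccncc1)C(C)C`: 5 mg/kg
Compound 2 `CCC(C)(C)/N=C(\NC#N)Nc1ccncc1`: 2.5 mg/kg

Among the compounds with values here, in a functional assay on the whole organism (blood, strain Wistar-Okamoto) with Rattus norvegicus as the target, with a stated time of 5 days (a lower number here means that less compound is needed, a higher number that more compound is needed for the effect), compound 2 gives 2.5 mg/kg, and the only measured step, a 2.0-fold lower number from compound 1 to compound 2 (0.30 log units; within the scatter), lies within the scatter, so compound 2 and compound 1 cannot be told apart on these numbers. Compound 3 `CC(C)(C)CC(C)(C)/N=C(\NC#N)Nc1ccncc1` differs from compound 2 by tert-butyl in place of methyl on a saturated chain carbon, two bonds along the chain from a double-bonded nitrogen. Within the data shown here, the one step that bears on it also altered the chain on the double-bonded nitrogen and stayed within the scatter, so no step beyond the scatter is expected here either. For compound 3 a value of 3 mg/kg is estimated, with a range from 1.2 mg/kg to 8 mg/kg, which means an expected step of a 1.2-fold higher number from compound 2 to compound 3 (0.08 log units; within the scatter).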

Compound 3, minimum effective dose: 50 mg/kg
Estimate against measurement, compound 3: 17-fold (1.22 log units) below; the measured number lies above the stated range.
By their numbers in this assay, from the lowest: compounds 2 and 1 (each within the scatter of the next); then compound 3.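

Earlier, changing the chain on the double-bonded nitrogen stayed within the scatter, which made the chain look tolerant of change. This result shows a limit to that tolerance: in this assay, tert-butyl in place of methyl on a saturated chain carbon, two bonds along the chain from a double-bonded nitrogen, gives a 20-fold higher number from compound 2 to compound 3 (1.30 log units; beyond the scatter), so much more compound is needed. Nothing available explains this jump. Open, on these data alone, is whether ethyl or isopropyl in place of that methyl would keep the dose close to that of compound 2, or whether the requirement climbs only with tert-butyl. A hydroxyl or an amine at this place also remains to be compared.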